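Aryl swap on the shared core: compound 2 to compound 3

The source may hold more compounds than are shown below. What is called first, only, known or untested is meant among the compounds shown, and "the series" means these compounds.

Two members of the series have been measured in an assay on T-REx-293 cells for inhibition of potassium channel subfamily T member 1 (Homo sapiens), read by patch clamp; on this read-out higher numbers stand for weaker inhibition and lower numbers for stronger inhibition. Compound 1 `Cc1cccc(-c2nc(C(C)NC(=O)c3cc(C(F)(F)F)nn3C)no2)c1` gives 977 nM. Compound 2 `Cc1ccnc(-c2noc([C@H](C)NC(=O)c3cc(C(F)(F)F)nn3C)n2)c1` gives 4470 nM, the highest number of the two; its nearest neighbour is compound 1, whose number is lower by a margin beyond the scatter. For the measured compounds named here, no pair among the measured compounds differs in a single place, so no single-change step is available to calibrate against.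

Compound 3 `CNc1cc(-c2noc([C@H](C)NC(=O)c3cc(C(F)(F)F)nn3C)n2)ccn1` has not been measured. It differs from compound 2 by 2-(methylamino)pyridin-4-yl in place of 4-methylpyridin-2-yl on an aromatic carbon. Nothing in the measured pair bears directly on this change, since compound 1 and compound 2 differ in more than one place.

Going by the values given here, with no comparable step on record, the step from compound 2 to compound 3 is expected to be modest, a 1.5-fold lower number from compound 2 to compound 3 (0.17 log units; within the scatter), leaning toward a lower number only because compound 2 sits at the top of the range with 4470 nM. Compound 3 is therefore expected to give 3000 nM, with a range from 800 nM to 12000 nM.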

Compound 3, half-maximal inhibitory concentration: 195 nM
Beside the measured number, compound 3's estimate is 15-fold (1.19 log units) above it, outside the stated range (below it).
By their numbers in this assay, from the lowest: compound 3; then compound 1; then compound 2.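

In this assay, for the compounds shown here, the aromatic carbon between two ring nitrogen atoms proves highly sensitive to the aryl group it carries: 2-(methylamino)pyridin-4-yl in place of 4-methylpyridin-2-yl gives a 23-fold lower number from compound 2 to compound 3 (1.36 log units; beyond the scatter), the first single-place step and one well beyond the scatter. The entering group has 1 hydrogen-bond donor and 2 hydrogen-bond acceptors against 0 and 1 for the group that leaves, so stronger inhibition is compatible with a larger, nitrogen-substituted aryl group at this position. The swap alters the substituent and the pyridine attachment together, and no measurement here accounts for the size of the step.

The compounds shown leave open whether the step belongs to the methylamino group or to the change from a pyridin-2-yl to a pyridin-4-yl attachment. A 2-methylpyridin-4-yl group, or a primary amine or dimethylamino group in place of the methylamino group, would help separate these contributions, while a longer chain on that nitrogen would show how far the substituent can extend.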